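Second methoxy on the phenoxy ring: compound 3

The compounds below may be only part of what the source reports. "The series", "measured", "known", "first", "only" and "open" are said of these compounds alone.

Of the compounds shown here, two have been measured in a functional assay on CCRF-CEM cells (Homo sapiens) for antiproliferative activity, read by cell counting, with a stated time of 96 h; on this read-out higher numbers stand for weaker inhibition and lower numbers for stronger inhibition. Compound 1 `CC(Nc1ccccc1Oc1ccc(Cl)cc1)=C1C(=O)CC(c2ccccc2)CC1=O` gives 190 nM and compound 2 `COc1cccc(Oc2ccccc2NC(C)=C2C(=O)CC(c3ccccc3)CC2=O)c1` gives 41 nM. Among the measured compounds shown here, the one step between them, a 4.6-fold lower number from compound 1 to compound 2 (0.67 log units; beyond the scatter), is 3-methoxyphenyl in place of 4-chlorophenyl on the oxygen of the aromatic ring. For the measured compounds named here, compound 2 thus stands at the lowest of the two numbers so far, with compound 1 as the only comparator at a higher number.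

Compound 3 `COc1ccc(Oc2ccccc2NC(C)=C2C(=O)CC(c3ccccc3)CC2=O)cc1OC` is not yet measured. It differs from compound 2 by methoxy in place of hydrogen on an aromatic carbon, turning 3-methoxyphenoxy into 3,4-dimethoxyphenoxy, the new group ortho to the methoxy already present and para to the large group. Going by the values given here, no measured step adds a methoxy to a ring already carrying one; the only known step swaps one whole aryl group for another, so it shows that this ring can move the read-out beyond the scatter but fixes no direction for a second methoxy. The expectation for compound 3 in this assay is therefore a small step, a 1.2-fold higher number from compound 2 to compound 3 (0.09 log units; within the scatter), within or near the scatter. The estimate for compound 3 is 50 nM, with a range from 18 nM to 150 nM.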

Compound 3, half-maximal inhibitory concentration: 160 nM
For compound 3 the middle estimate is 3.2-fold (0.51 log units) below the measured one; the measured number lies above the stated range.
By their numbers in this assay, from the lowest: compound 2; then compounds 3 and 1 (each within the scatter of the next).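

A second methoxy on this ring is not neutral in this assay: the change to 3,4-dimethoxyphenoxy gives a 3.9-fold higher number from compound 2 to compound 3 (0.59 log units; beyond the scatter), the first measured sign that the aromatic carbon para to the large group and ortho to the existing methoxy responds to substitution. The advantage of 3-methoxyphenyl over 4-chlorophenyl does not survive this addition, since the comparison with the chlorinated compound gives a 1.2-fold lower number from compound 1 to compound 3 (0.07 log units; within the scatter), and compound 1 and compound 3 both carry a group other than hydrogen on that carbon, though two compounds fix no rule. Nothing available explains the higher number at this position.

Still open, from the compounds shown here alone, is whether the loss belongs to any group on this carbon or only to a methoxy alongside the one already present, a question that 4-methoxyphenyl, or a hydroxyl, fluorine or amine on the same carbon, would address. Equally open, going by these compounds, is whether a second methoxy placed elsewhere, as in 3,5-dimethoxyphenyl, would keep the low number of compound 2 at 41 nM.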